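Pyrazoline thiazolidinedione series: furan-2-yl replacement at the saturated carbon

The source may report more compounds than this note shows. Statements on the series, on what has been measured and on what is new or still open speak of the compounds shown alone.

Compound 1 `O=C1NC(=O)/C(=C\c2ccc(OCC(=O)N3N=C(c4ccccc4)CC3c3ccccc3)cc2)S1` in an assay on cells for inhibition of histone deacetylase 8 (Homo sapiens), read by fluorescence, with a stated time of 30 min (on this read-out lower numbers stand for stronger inhibition and higher numbers for weaker inhibition), gives 20000 nM. Compound 2 `O=C1NC(=O)/C(=C\c2ccc(OCC(=O)N3N=C(c4ccc(F)cc4)CC3c3ccccc3)cc2)S1` carries fluoro in place of hydrogen on an aromatic carbon; in this assay compound 2 gives only a limit, > 50000 nM, so it stands at the weak end of the numbers shown. The step of an at least 2.5-fold higher number from compound 1 to compound 2 (0.39 log units; beyond the scatter) is therefore known only as a lower bound, because of the limit of > 50000 nM in this assay, at which 1 of the 2 values shown sits.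

Compound 3 `O=C1NC(=O)/C(=C\c2ccc(OCC(=O)N3N=C(c4ccc(F)cc4)CC3c3ccco3)cc2)S1` differs from compound 2 by furan-2-yl in place of phenyl on a saturated ring carbon. For the measured compounds named here, no measured step touches this position; the only step in hand concerns the fluoro on the other aryl ring and bears on it indirectly at most. With compound 2 already at the limit, a number beyond the scatter in either direction cannot be anchored. Compound 3 is expected to stay near the limit, estimated at 60000 nM (range 20000 nM to 200000 nM), which corresponds to an expected step that the limit leaves unreadable from compound 2 to compound 3.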

Compound 3, half-maximal inhibitory concentration: > 50000 nM
Compound 3: no number, only a limit; the forecaster's own chance of this, stated with the estimate: 70%; the middle value lies beyond the limit too.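

No step can be read between compound 2 and compound 3, because both give only a limit and no number: the limit of > 50000 nM in this assay, at which 2 of the 3 values shown sit.

Still open, from the compounds shown here alone, is whether furan-2-yl in place of phenyl on a saturated ring carbon changes the inhibition at all, with or without the fluoro.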